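Shortening the aryl chain: an ethyl-to-methyl lipophilicity step

A few compounds are considered here, and "the series" means these few. Any claim that something is new, unique, unknown or untested is made for them only; others in the source may bear on it.

Two compounds of the series have numbers in a physicochemical assay for lipophilicity; on this read-out higher numbers stand for higher lipophilicity and lower numbers for lower lipophilicity. Compound 1 `CCc1ccccc1-c1nc(N)nc(N)n1` gives 1.65 in this assay, and compound 2 `Nc1nc(N)nc(-c2cc(Br)ccc2Br)n1` gives 2.09 in this assay. Compound 1 therefore stands lowest of the two, with compound 2 above it by a gap that lies beyond the scatter. Among the measured compounds shown here, no two measured compounds differ in only one place, so no measured single step is available to calibrate the change considered here. Compound 3 `Cc1ccccc1-c1nc(N)nc(N)n1` is not yet measured; it differs from compound 1 by hydrogen in place of methyl on a saturated chain carbon bound to an aromatic carbon. Losing one chain carbon is expected to lower the read-out, and the step is estimated as a number 0.50 log units lower from compound 1 to compound 3 (beyond the scatter), a drop larger than the scatter. On that basis compound 3 is expected to give about 1.15 in this assay, within a range from 0.85 to 1.45.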

Compound 3, partition coefficient: 1.26
The estimate for compound 3 lay 0.11 log units below the measured number; low and high end bracket the measured number.
By their numbers in this assay, from the lowest: compound 3; then compound 1; then compound 2.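

In this assay, among the compounds shown here, the ethyl-to-methyl change, hydrogen in place of methyl on a saturated chain carbon bound to an aromatic carbon, now has a measured size, with the read-out at a number 0.39 log units lower from compound 1 to compound 3 (beyond the scatter) as the first single-place step. For the compounds shown here, this position is therefore not silent on this read-out: removing one chain carbon here moves the number by more than the scatter, though only this one pair supports that reading. No accompanying measurement bears on why the step has this size.

Open, from the compounds shown here alone, is whether a propyl chain at the same place would continue the step in the same direction and at a similar size, and what an amine or a carboxylic acid on that chain would do. Compound 2 differs from compound 1 and compound 3 in more than one place, so it cannot show whether the step carries over to other substitution on the aryl ring.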